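Benzyl on the ring amide nitrogen: an untested step

A few compounds are considered here, and "the series" means these few. Any claim that something is new, unique, unknown or untested is made for them only; others in the source may bear on it.

Of the compounds shown here, three have been measured in a functional assay on Caco-2 cells (Homo sapiens) for antiproliferative activity, read by MTT assay; a higher number here means a weaker inhibitor, a lower number a stronger inhibitor. Compound 1 `CN1C(=O)/C(=C2\S/C(=N/c3ccc(S(N)(=O)=O)cc3)NC2=O)c2cc(Cl)ccc21` gives 42300 nM. Compound 2 `NS(=O)(=O)c1cccc(/N=C2\NC(=O)/C(=C3/C(=O)Nc4ccccc43)S2)c1` gives 12100 nM, and its bromo analogue, compound 3 `NS(=O)(=O)c1cccc(/N=C2\NC(=O)/C(=C3/C(=O)Nc4ccc(Br)cc43)S2)c1`, gives 10800 nM. Among these three numbers compound 2 stands second highest: compound 3 sits nearest, a step of a 1.1-fold lower number from compound 2 to compound 3 (0.05 log units; within the scatter), while compound 1 lies furthest away, beyond the scatter, though it differs from compound 2 in several places at once.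

Compound 4 `NS(=O)(=O)c1cccc(/N=C2\NC(=O)/C(=C3/C(=O)N(Cc4ccccc4)c4ccccc43)S2)c1` has not yet been measured. It differs from compound 2 by benzyl in place of hydrogen on an amide-type nitrogen in a ring. Among the measured compounds shown here, no measured step touches this ring nitrogen, so the only single-place step available, from compound 2 to compound 3, does not speak to it. With nothing directly comparable, compound 4 is expected to give a number close to that of compound 2, perhaps somewhat higher; the estimated step is a 1.5-fold higher number from compound 2 to compound 4 (0.17 log units; within the scatter). The estimate for compound 4 is therefore 18000 nM, within a range from 6000 nM to 55000 nM.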

Compound 4, half-maximal inhibitory concentration: 103000 nM
Compound 4: the middle estimate sits 5.7-fold (0.76 log units) below what was measured, outside the stated range (above it).
By their numbers in this assay, from the lowest: compounds 3 and 2 (each within the scatter of the next); then compound 1; then compound 4.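

In this assay, the ring amide nitrogen of compound 2 proves sensitive to change: benzyl in place of the amide hydrogen gives an 8.5-fold higher number from compound 2 to compound 4 (0.93 log units; beyond the scatter), so compound 4 is a weaker inhibitor. The only earlier single-place step, a 1.1-fold lower number from compound 2 to compound 3 (0.05 log units; within the scatter), put bromo on an aromatic carbon and showed nothing about this nitrogen, which is now the one place shown where a single change moves the number beyond the usual scatter. No data here explain why this benzyl group weakens the antiproliferative effect.

With benzyl as the only group shown on this nitrogen in this series, it remains open whether ethyl, a longer chain or a chain ending in an amine would raise the number as well. Also open, going by these compounds, is whether bromo on the aromatic carbon would change the outcome when combined with benzyl.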